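The source may report more compounds than this note shows. Statements on the series, on what has been measured and on what is new or still open speak of the compounds shown alone.

Measured compounds:
- compound 1, `CC(C)C(c1ncco1)c1ccc(-c2ccc3cccc(F)c3c2)[nH]c1=O`: 64 nM
- compound 2, `CC(C)C(c1ccc(-c2ccc3cccc(F)c3c2)[nH]c1=O)N1CCN/C1=N\C#N`: 38 nM
- compound 3, `CC(C)C(c1nnc[nH]1)c1ccc(-c2ccc3cccc(F)c3c2)[nH]c1=O`: 21 nM

All three were run in a functional assay on CHO cells for antagonist activity at prostaglandin E2 receptor EP3 subtype (Homo sapiens), read by cAMP accumulation; a lower number here means a stronger inhibitor, a higher number a weaker inhibitor. Within this trio, compound 3 shows the lowest number in this assay, but its separation from compound 2 is a 1.8-fold lower number from compound 2 to compound 3 (0.26 log units; within the scatter), so the two cannot be ordered; only the move a 3.0-fold lower number from compound 1 to compound 3 (0.48 log units; beyond the scatter) is a step beyond the scatter, and it is a modest one. The move a 1.7-fold lower number from compound 1 to compound 2 (0.23 log units; within the scatter) is likewise within the scatter.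

Compound 4, `CC(C)C(Nc1nccs1)c1ccc(-c2ccc3cccc(F)c3c2)[nH]c1=O`, has not yet been measured in this assay. Relative to compound 3 the change is (1,3-thiazol-2-yl)amino in place of 4H-1,2,4-triazol-3-yl on a saturated chain carbon bound to an aromatic carbon and a saturated chain carbon. The measured steps that bear on this are the three swaps at the same saturated chain carbon: the move from compound 1 to compound 3 and the two within-scatter moves among compounds 1, 2 and 3. All three swaps at this carbon kept the numbers inside a narrow band, so a small effect is expected here too; since the entering group is an aromatic five-membered ring with 2 hetero atoms, as in compound 1, a small rise toward the value of compound 1 is the more likely direction, though this may well stay within the scatter.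

Compound 4 is therefore estimated at 40 nM (range 15 nM to 110 nM), corresponding to an expected step of a 1.9-fold higher number from compound 3 to compound 4 (0.28 log units; within the scatter).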

Compound 4, half-maximal inhibitory concentration: 10 nM
For compound 4 the middle estimate is 4.0-fold (0.60 log units) above the measured one; measured number below the stated range.
By their numbers in this assay, from the lowest: compound 4; then compounds 3, 2 and 1 (each within the scatter of the next, the first and the last beyond it).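

In this assay, for the compounds shown here, the change at the saturated chain carbon gives a 2.1-fold lower number from compound 3 to compound 4 (0.32 log units; beyond the scatter), so this position can move the number beyond the scatter even from the lowest value among the earlier compounds. The further steps, a 3.8-fold lower number from compound 2 to compound 4 (0.58 log units; beyond the scatter) and a 6.4-fold lower number from compound 1 to compound 4 (0.81 log units; beyond the scatter), are also beyond the scatter, making compound 4 the strongest inhibitor of the four, and the last step is the widest seen at this carbon, though still modest. Compound 1 and compound 4 both carry a five-membered aromatic ring with 2 hetero atoms yet sit at opposite ends of the series, so that ring description alone does not set the order, and no measurement here accounts for the difference.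

The compounds shown do not separate the contribution of the thiazole ring from that of the amino link, since 1,3-thiazol-2-yl attached directly to this carbon and (1,3-oxazol-2-yl)amino would each change only one of the two. Also open, on these data alone, is what an N-methyl group on the linking nitrogen, or a phenylamino group in place of the thiazolylamino group, would do to the number.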